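Trimming the methyl of compound 2: an estimate for compound 3

The source may report more compounds than this note shows. Statements on the series, on what has been measured and on what is new or still open speak of the compounds shown alone.

Compound 1 `Cn1c(-c2ccc(O)cc2)nc2c(NC3CCCC3)ncnc21` gives 66 nM in a functional assay (strain BALB/C) for antagonist activity at adenosine receptor A1 (Mus musculus), with a stated time of 1 h, tested at 1 uM; a higher number here means a weaker inhibitor, a lower number a stronger inhibitor. Compound 2 `Cc1ccc(-c2nc3c(NC4CCCC4)ncnc3n2C)cc1` gives 177 nM in this assay.

Among the compounds with values here, of these two numbers, compound 2 has the higher one; its only neighbour is compound 1, reached by the step of a 2.7-fold higher number from compound 1 to compound 2 (0.43 log units; beyond the scatter), which swaps hydroxy for methyl on the aromatic carbon. Compound 3 `Cn1c(-c2ccccc2)nc2c(NC3CCCC3)ncnc21` has yet to be measured in this assay. It differs from compound 2 by hydrogen in place of methyl on an aromatic carbon. Within the data shown here, the single measured step concerns a hydroxy giving way to methyl, not a methyl giving way to hydrogen, so no measured step bears directly on this change; the data offer no precedent for it. The change removes one carbon and leaves donors and acceptors unchanged, so a shift within the scatter, or a small one in either direction, is expected. Compound 3 is therefore estimated at 150 nM, with a range from 70 nM to 350 nM, which means an expected step of a 1.2-fold lower number from compound 2 to compound 3 (0.07 log units; within the scatter).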

Compound 3, antagonist equilibrium constant: 17 nM
Beside the measured number, compound 3's estimate is 8.8-fold (0.95 log units) above it, outside the stated range (below it).
By their numbers in this assay, from the lowest: compound 3; then compound 1; then compound 2.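

In this assay the change from 4-methylphenyl to phenyl gives the largest step seen at this position (a 10-fold lower number from compound 2 to compound 3 (1.02 log units; beyond the scatter)), which the earlier pair, holding only hydroxy and methyl, could not show. Hydrogen also improves on hydroxy (a 3.9-fold lower number from compound 1 to compound 3 (0.59 log units; beyond the scatter)), so both groups tested on this aromatic carbon give a higher number than the unsubstituted phenyl, and compound 3 stands lowest of the three, with both of its steps beyond the scatter. Within the data shown here, nothing available explains why losing one carbon moves the number so far.

Going by these compounds, whether hydrogen would also give a lower number than other groups at this place on the ring, such as fluorine, methoxy or an amine, remains open. On these data alone, it is also open how a longer chain such as ethyl, or a carboxylic acid, would fare there.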